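Stripping one arm from an inactive pair

This account rests on a few compounds, and the source may have more. Where it says the series, first, only, none or still open, it means among the compounds named here.

Compound 1 `c1ccc(CN(CCCCN(C[C@H]2Cc3ccccc3CN2)[C@H]2CCCc3cccnc32)Cc2ccccn2)nc1` and compound 2 `c1cncc(CN(CCCCN(C[C@H]2Cc3ccccc3CN2)[C@H]2CCCc3cccnc32)Cc2cccnc2)c1` share the same core and differ only in the aromatic arms on one amine nitrogen. In a functional assay on cells for agonist activity at C-X-C chemokine receptor type 4 (Homo sapiens), read by fluorescence and calcium flux, with a stated time of 90 s (a lower number here means that less compound is needed, a higher number that more compound is needed for the effect), compound 1 gives only a limit, > 30000 nM. Compound 2 likewise reaches only a limit in this assay, > 30000 nM. Among the compounds with values here, both values therefore sit at the limit of > 30000 nM in this assay, at which 2 of the 2 values shown sit, so neither compound shows a measurable effect, and no step between measured compounds can be sized. Compound 3 `c1cncc(CNCCCCN(C[C@H]2Cc3ccccc3CN2)[C@H]2CCCc3cccnc32)c1` is not yet measured; it differs from compound 2 by a single change, (hydrogen in place of (pyridin-3-yl)methyl on an amine nitrogen), that is, hydrogen in place of (pyridin-3-yl)methyl on an amine nitrogen. Nothing among the compounds shown speaks for a gain from this change, so the expected step of a number no higher from compound 2 to compound 3 (the limit leaves the size open) is none beyond the scatter. Compound 3 is thus expected to give about 30000 nM, most likely again reported only as a limit, within 10000 nM to 100000 nM.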

Compound 3, half-maximal effective concentration: > 30000 nM
Compound 3 ended at the assay's limit (the forecaster's own chance of this, stated with the estimate: 75%); the middle value lies on the limit itself.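

In this assay compound 3 gives only a limit, > 30000 nM. Within the data shown here, compound 2 also stands at a limit, so no step between these two compounds can be read. The compounds shown leave open whether hydrogen in place of (pyridin-3-yl)methyl changes the effect at all.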